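The source may report more compounds than this note shows. Statements on the series, on what has been measured and on what is new or still open speak of the compounds shown alone.

Measured so far in an ADME assay on microsomes from liver (Homo sapiens) for metabolic stability, read by LC-MS, tested at 1 mM; on this read-out lower numbers stand for a shorter-lived compound and higher numbers for a longer-lived compound:
- compound 1 `N#Cc1ccc(F)cc1Cn1c(N2CCC[C@@H](N)C2)nc2c(F)c[nH]c2c1=O` gives 1.64 h
- compound 2 `N#Cc1ccc(F)cc1Cn1c(N2CCC[C@@H](N)C2)nc2c(-c3ccc(S(N)(=O)=O)cc3)c[nH]c2c1=O` gives > 3.33 h (a limit of the assay)
- compound 3 `CS(=O)(=O)c1ccc(-c2c[nH]c3c(=O)n(Cc4cc(F)ccc4C#N)c(N4CCC[C@@H](N)C4)nc23)c(F)c1` gives > 3.33 h (a limit of the assay)

Compound 3 stands at > 3.33 h, which is a limit and not a number. Across the series the picture is the limit of > 3.33 h in this assay, at which 2 of the 3 values shown sit, and only compound 1 has a number. Next comes compound 4 `CS(=O)(=O)c1cccc(-c2c[nH]c3c(=O)n(Cc4cc(F)ccc4C#N)c(N4CCC[C@@H](N)C4)nc23)c1`, with 3-(methylsulfonyl)phenyl in place of 2-fluoro-4-(methylsulfonyl)phenyl on an aromatic carbon.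

Going by the values given here, three measured steps bear on this change. Replacing the fluoro of compound 1 with an aryl group gave an at least 2.0-fold higher number from compound 1 to compound 2 (0.30 log units; that floor lies within the scatter) and also an at least 2.0-fold higher number from compound 1 to compound 3 (0.30 log units; that floor lies within the scatter). Between the two aryl compounds there is a step that the two limits leave unreadable from compound 2 to compound 3. Among the compounds with values here, no measured pair shows the loss of the fluoro group on its own. Compound 4 still carries an aryl group in place of the fluoro of compound 1, so no step beyond the scatter is expected in this assay, in either direction. The expected step is a step that the limit leaves unreadable from compound 3 to compound 4, an estimate that starts from a limit. For compound 4 the estimated value is 3.5 h, with an expected range from 1.8 h to 7 h, and the assay may well report only a limit.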

Compound 4, half-life: > 3.33 h
Compound 4 gave a limit, no number; the forecaster's own chance of this, stated with the estimate: 60%; the middle value does not contradict the limit.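

In this assay, a third aryl group on the aromatic carbon two ring bonds from the ring nitrogen gives the same kind of result as the first two: an at least 2.0-fold higher number from compound 1 to compound 4 (0.30 log units; that floor lies within the scatter). Compound 4 carries 3-(methylsulfonyl)phenyl, with no fluoro on that ring, so the 2-fluoro-4-(methylsulfonyl)phenyl group of compound 3 is not required for a compound of this series to reach the limit of the assay. The steps among compound 2, compound 3 and compound 4 cannot be read because all three stand at a limit and none has a number: the limit of > 3.33 h in this assay, at which 3 of the 4 values shown sit.

From the compounds shown here alone, how far each of these aryl compounds lies past the limit remains open, so the three aryl groups cannot be ranked, and the floors of their steps from compound 1 do not clear the usual scatter. Also open, going by these compounds, is whether an aryl group is needed here at all, a question that a methyl group, an amine or a carboxylic acid in place of the fluoro of compound 1 would address in this assay.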